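Fluorine next to the sulfonamide in a pivalate ester series

The source may report more compounds than this note shows. Statements on the series, on what has been measured and on what is new or still open speak of the compounds shown alone.

Measured so far:
compound 1 `Cc1ccc(CC(CNC(=O)C(C)(C)c2ccc(NS(C)(=O)=O)cc2)COC(=O)C(C)(C)C)cc1C` — 104 nM
compound 2 `C[C@@H](C(=O)NC[C@@H](COC(=O)C(C)(C)C)Cc1ccccc1)c1ccc(NS(C)(=O)=O)c(F)c1` — 205 nM

Of the compounds shown here, two have been tested in a functional assay on CHO cells for antagonist activity at transient receptor potential cation channel subfamily V member 1 (Rattus norvegicus); on this read-out lower numbers stand for stronger inhibition and higher numbers for weaker inhibition. Compound 1 gives 104 nM, and compound 2 gives 205 nM. Going by the values given here, compound 1 has the lowest of the two numbers; compound 2 differs from it in more than one place, and the gap between them lies within the scatter, so the two values show no ordering of the pair. Among the compounds with values here, no step between two measured compounds that differ in a single place has been recorded.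

Compound 3 `Cc1ccc(CC(CNC(=O)C(C)(C)c2ccc(NS(C)(=O)=O)c(F)c2)COC(=O)C(C)(C)C)cc1C` is the next compound to be measured. It differs from compound 1 by fluoro in place of hydrogen on an aromatic carbon, the fluoro entering ortho to a methanesulfonamido group and meta to a large group. Within the data shown here, no measured pair in this set isolates that change, so its effect is not known from the data. Compound 3 is expected to give a number close to that of compound 1, and the estimated step of a 1.7-fold lower number from compound 1 to compound 3 (0.24 log units; within the scatter) runs toward a lower number but is not expected to clearly exceed the scatter. On that basis compound 3 is estimated at 60 nM, with a range from 25 nM to 150 nM.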

Compound 3, inhibition constant: 65 nM
For compound 3 the middle estimate is 1.1-fold (0.03 log units) below the measured one; the range from low to high includes it.
By their numbers in this assay, from the lowest: compounds 3, 1 and 2 (each within the scatter of the next, the first and the last beyond it).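

Fluoro in place of hydrogen on an aromatic carbon, ortho to a methanesulfonamido group, gives a 1.6-fold lower number from compound 1 to compound 3 (0.20 log units; within the scatter) in this assay and is the first step in this set that isolates a single place. The earlier compounds shown here could not show how this position responds to the change, whereas this pair shows that the 3-fluoro-4-(methanesulfonamido)phenyl group is tolerated on the core of compound 1, and no gain or loss can be read from a step of this size. Nothing available bears on why the step has this size.

From the compounds shown here alone, whether the same step would hold in compound 2, which carries the same fluoro group but differs from compound 1 in other places as well, stays open. Also open, going by these compounds, is how chloro, methyl or methoxy would compare with fluoro at this same place, and whether the position would accept anything larger than a single atom.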